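Trimming the side group of compound 1

The source may hold more compounds than are shown below. What is called first, only, known or untested is meant among the compounds shown, and "the series" means these compounds.

Measured so far in an ADME assay on MDCK cells (Canis lupus familiaris) for permeability, read by LC-MS, with a stated time of 90 min, tested at 2 uM; a lower number here means that the compound crosses the layer more slowly, a higher number that the compound crosses the layer faster:
- compound 1 `Cc1cc(C)c(CN2CCc3c(Cl)cc([C@H](CO)[C@H]4CCOC4)c(Cl)c3C2=O)c(=O)[nH]1` gives 2.9 10^-6 cm/s
- compound 2 `COC(c1cc(Cl)c2c(c1Cl)C(=O)N(Cc1c(C)cc(C)[nH]c1=O)CC2)C1CCN(C2COC2)CC1` gives 7 10^-6 cm/s; 7.9 10^-6 cm/s (2 entries)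
- compound 3 `COC(c1cc(Cl)c2c(c1Cl)C(=O)N(Cc1c(C)cc(C)[nH]c1=O)CC2)C1CCN(C(=O)CO)CC1` gives 7.3 10^-6 cm/s; 7.1 10^-6 cm/s (2 entries)

Compound 1 stands on one single number, 2.9 10^-6 cm/s, while the other two compounds each have two entries (the several entries of compound 2 in this assay, 7 10^-6 cm/s; 7.9 10^-6 cm/s (2 entries); (the several entries of compound 3 in this assay, 7.3 10^-6 cm/s; 7.1 10^-6 cm/s (2 entries))). Both of those sets of entries show higher numbers than compound 1 does.

Compound 4 `Cc1cc(C)c(CN2CCc3c(Cl)cc([C@H](C)CO)c(Cl)c3C2=O)c(=O)[nH]1` has not been measured yet. It keeps the core of compound 1 and changes one group: a group of 4 heavy atoms (3 carbon, 1 oxygen; no ring) in place of a group of 8 heavy atoms (6 carbon, 2 oxygen; one five-membered non-aromatic ring with 1 hetero atom), on an aromatic carbon. A 1-(hydroxymethyl)ethyl group takes the place of the larger group with the five-membered non-aromatic ring, on the same aromatic carbon.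

Within the data shown here, no measured pair isolates this change, so the expectation in this assay is loose. A small upward move is expected, resting only on compound 2 at 7 10^-6 cm/s; 7.9 10^-6 cm/s (2 entries) and compound 3 at 7.3 10^-6 cm/s; 7.1 10^-6 cm/s (2 entries), which carry other side groups. The expected step is a 1.7-fold higher number from compound 1 to compound 4 (0.24 log units; within the scatter), which is no larger than the usual scatter. For compound 4 the estimated value is 5 10^-6 cm/s, within an expected range of 2.5 10^-6 cm/s to 10 10^-6 cm/s.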

Compound 4, apparent permeability: 12.4 10^-6 cm/s
Estimate against measurement, compound 4: 2.5-fold (0.39 log units) below, and the stated range ends below it.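

In this assay, putting 1-(hydroxymethyl)ethyl in place of the larger group with the five-membered non-aromatic ring, on the same aromatic carbon, gives a 4.3-fold higher number from compound 1 to compound 4 (0.63 log units; beyond the scatter). Among these compounds, this is the first comparison here in which only one place differs, and it shows that the group on this carbon can move the read-out by more than the usual scatter. Nothing measured in these compounds explains why the number rises.

A single pair cannot separate the part played by the ring itself from that of the group's size or its stereocentres. As far as these compounds go, how the number would respond to other groups on this carbon, such as an amine, a carboxylic acid or a longer chain, also remains open.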